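Methyl gives way to 2-carboxyethoxy on an aromatic nitrogen

A few compounds are considered here, and "the series" means these few. Any claim that something is new, unique, unknown or untested is made for them only; others in the source may bear on it.

In a functional assay on a cell-free system (plasma, Oryctolagus cuniculus) for inhibition, with stated times of 5 min, 1 min and 6 min (a higher number here means a weaker inhibitor, a lower number a stronger inhibitor), compound 3 (`CCOC(=O)c1c(C)nc(-c2cccc(C#N)c2)n1C`) gives 22100 nM as its result, within the scatter of compound 1 (`CCOC(=O)c1c(C)nc(-c2ccccc2C#N)n1OC`), which gives 14900 nM as its result. Compound 2 (`CCOC(=O)c1c(C)nc(-c2ccccc2)n1OC`) gives > 30000 nM as a limit of the assay, not a number. Results in this set can thus end at a ceiling, as the limit of > 30000 nM in this assay, at which 1 of the 3 values shown sits, makes plain.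

Compound 4 (`CCOC(=O)c1c(C)nc(-c2cccc(C#N)c2)n1OCCC(=O)O`) departs from compound 3 in one place, with 2-carboxyethoxy in place of methyl on an aromatic nitrogen. For the measured compounds named here, the one measured step, an at least 2.0-fold higher number from compound 1 to compound 2 (0.30 log units; that floor lies within the scatter), puts hydrogen in place of cyano on an aromatic carbon. It leaves that nitrogen untouched, so it bears on the new change only indirectly. Going by the values given here, no measured step shows what a new group on that nitrogen does, so its size cannot be read from the data.

The expectation rests on compound 3 at 22100 nM as the starting point, with no shift beyond the scatter expected in this assay and with wide margins. The estimated step is a 1.1-fold lower number from compound 3 to compound 4 (0.04 log units; within the scatter) as a cautious guess. For compound 4 the expected value is 20000 nM with an estimated range of 6000 nM to 45000 nM in most repeat measurements.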

Compound 4, half-maximal inhibitory concentration: > 30000 nM
Compound 4 was reported as a limit; the forecaster's own chance of this, stated with the estimate: 40%; middle value at least 1.5-fold (0.17 log units) from the limit.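

In this assay compound 4 is reported only as a limit of the assay, > 30000 nM, and not as a number. As far as these compounds go, putting 2-carboxyethoxy in place of methyl on the aromatic nitrogen gives an at least 1.3-fold higher number from compound 3 to compound 4 (0.13 log units; that floor lies within the scatter), so this much larger group brings no sign of stronger inhibition, while the true size of the step stays unknown, with only its floor printed and that floor inside the usual scatter. This is the only step shown at this nitrogen, and it tells that the position does not turn the series into a clearly stronger inhibitor with this group, while the ceiling now holds more of the set: the limit of > 30000 nM in this assay, at which 2 of the 4 values shown sit.

From the compounds shown here alone, what stays open is whether the result follows from the length of the chain or from the group at its end, since this one change alters both at once. A plain propoxy chain, a 2-hydroxyethoxy chain or an amine at the end of the chain would pull those two apart, and none of these stands among the compounds shown.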